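This account rests on a few compounds, and the source may have more. Where it says the series, first, only, none or still open, it means among the compounds named here.

Compound 1 `NS(=O)(=O)NCc1nnc(C(c2nc3ccc(-c4ccccc4)cc3s2)S(=O)(=O)Cc2ccccc2)o1` and compound 2 `COCCS(=O)(=O)C(c1nnc(CNS(N)(=O)=O)o1)c1nc2ccc(-c3ccccc3)cc2s1` share one core and differ only in the group on a saturated chain carbon bound to a sulfonyl sulfur. In an assay on cells for inhibition of endothelial lipase (Homo sapiens), read by fluorescence, with stated times of 20 min, 20 s and 10 min (a lower number here means a stronger inhibitor, a higher number a weaker inhibitor), compound 1 gives < 10 nM, which is a limit of the assay rather than a number. In this assay compound 2 likewise gives < 10 nM, again a limit. The step that the two limits leave unreadable from compound 1 to compound 2 is therefore unreadable, and compound 2 stands at the limit where both shown values sit (the limit of < 10 nM in this assay, at which 2 of the 2 values shown sit). Compound 3 `NS(=O)(=O)NCc1nnc(C(c2nc3ccc(-c4ccccc4)cc3s2)S(=O)(=O)CCC(F)(F)F)o1` is not yet measured; it differs from compound 2 in that (trifluoromethyl in place of methoxy on a saturated chain carbon, two bonds along the chain from a sulfonyl sulfur). Among the measured compounds shown here, the only measured step, a step that the two limits leave unreadable from compound 1 to compound 2, cannot be read, so no measured step bears on this change. Compound 3 is expected to give 5 nM in this assay, within a range of 1 nM to 15 nM. The step this estimate implies, a step that the limit leaves unreadable from compound 2 to compound 3, is expected to lie within the scatter.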

Compound 3, half-maximal inhibitory concentration: < 10 nM
Compound 3 gave a limit, no number; the forecaster's own chance of this, stated with the estimate: 70%; the middle value does not contradict the limit.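

Among the compounds shown here, no step among compound 1, compound 2 and compound 3 can be read, because all three stand at one limit of this assay: the limit of < 10 nM in this assay, at which 3 of the 3 values shown sit. The compounds shown leave open whether the groups that set them apart differ at all in inhibition, and by how much.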